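A Fluorine Where a Methyl Once Helped

This account rests on a few compounds, and the source may have more. Where it says the series, first, only, none or still open, it means among the compounds named here.

Compound 1: `Cc1ccc(S(=O)(=O)N2CCN(c3ncc(C(=O)NO)s3)CC2)cc1` — 350 nM
Compound 2: `O=C(NO)c1cnc(N2CCN(S(=O)(=O)c3ccccc3)CC2)s1` — 10000 nM

In a functional assay on MCF7 cells (Homo sapiens) for antiproliferative activity (a higher number here means a weaker inhibitor of growth, a lower number a stronger inhibitor of growth), compound 2 gives 10000 nM, the highest of the two measured numbers. Its nearest neighbour is compound 1, which gives 350 nM. The step between them, a 29-fold higher number from compound 1 to compound 2 (1.46 log units; beyond the scatter), came from a hydrogen in place of a methyl on the ring that carries the sulfonyl group.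

Compound 3, `O=C(NO)c1cnc(N2CCN(S(=O)(=O)c3ccc(F)cc3)CC2)s1`, puts a substituent back at that same place: fluoro in place of hydrogen on an aromatic carbon. Going by the values given here, the only measured step that bears on this is the one from compound 1 to compound 2, where taking a small group away raised the number greatly. Putting a fluoro in is therefore expected to lower the number, though a fluoro is not a methyl and the data cannot show how much of the loss is recovered. Compound 3 is expected to give about 2000 nM, within 500 nM to 8000 nM. That expectation means a 5.0-fold lower number from compound 2 to compound 3 (0.70 log units; beyond the scatter).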

Compound 3, concentration for 50% growth inhibition: 3500 nM
Beside the measured number, compound 3's estimate is 1.8-fold (0.24 log units) below it; low and high end bracket the measured number.
By their numbers in this assay, from the lowest: compound 1; then compound 3; then compound 2.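

In this assay, a fluoro on this aromatic carbon, para to a large group, recovers only part of what was lost when the methyl was removed, giving a 2.9-fold lower number from compound 2 to compound 3 (0.46 log units; beyond the scatter) as its gain over hydrogen. The earlier pair showed only that methyl and hydrogen differ here; these compounds show that the identity of the group matters, not just the presence of one, since a 10-fold higher number from compound 1 to compound 3 (1.00 log units; beyond the scatter) still separates fluoro from methyl. Nothing given here explains why the methyl gives the lower number of the two.

Going by these compounds, whether a chloro, a methoxy group or an amine on this carbon would match the methyl or fall short of it remains open. So does whether a fluoro or methyl on another carbon of the same ring would give a similar number.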